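Two limits and one open position in this assay

The source may hold more compounds than are shown below. What is called first, only, known or untested is meant among the compounds shown, and "the series" means these compounds.

Compound 1 `CCC(C)C1NC(=O)N(C2CCCC2)C1=O` and compound 2 `O=C1NC(c2ccccc2)C(=O)N1Cc1ccccc1` have both been tested in a functional assay on CCRF-CEM cells (Homo sapiens) for inhibition; a lower number here means a stronger inhibitor, a higher number a weaker inhibitor. In this assay compound 1 gives > 200000 nM, which is a limit of the assay and not a number. Compound 2 gives > 200000 nM in this assay, again a limit rather than a measured number. Within the data shown here, compound 2 therefore stands at the limit of > 200000 nM in this assay, at which 2 of the 2 values shown sit, alongside compound 1; no measured step between the two exists, and the pair shows only that neither reached a measurable inhibition.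

Compound 3 `CCC(C)C1NC(=O)N(Cc2ccccc2)C1=O` carries the sec-butyl of compound 1 together with the benzyl of compound 2. Against compound 2 the change is sec-butyl in place of phenyl on a saturated ring carbon. Since compound 1 and compound 2 both sit at the limit of > 200000 nM in this assay, at which 2 of the 2 values shown sit, there is no measured direction to carry over. The step from compound 2 to compound 3 is expected to be a step that the limit leaves unreadable from compound 2 to compound 3, nothing beyond the scatter in this assay. Compound 3 is accordingly estimated at 300000 nM, with a range of 100000 nM to 1000000 nM, and most probably reported only as a limit.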

Compound 3, half-maximal inhibitory concentration: > 200000 nM
Compound 3 ended at the assay's limit (the forecaster's own chance of this, stated with the estimate: 85%); the middle value is on the limit's open side.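

In this assay compound 3 gives > 200000 nM, a limit of the assay and not a number. No step from compound 2 to compound 3 can be read, because both compounds sit at the same limit: the limit of > 200000 nM in this assay, at which 3 of the 3 values shown sit.

The compounds shown leave open whether sec-butyl and phenyl differ at all in this assay, and which change to the shared core, if any, gives a measurable inhibition.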